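The source may report more compounds than this note shows. Statements on the series, on what has been measured and on what is new or still open speak of the compounds shown alone.

Working notes on the aryl-ether piperidine series in an assay on microsomes from liver for inhibition of acyl-CoA desaturase 1 (Rattus norvegicus); a lower number here means a stronger inhibitor, a higher number a weaker inhibitor. Among the compounds with values here, compound 1 `Cc1ccccc1OC1CCN(c2ccc(-n3ccnc3)nn2)CC1` gives 39 nM and compound 2 `Cc1cccc(OC2CCN(c3ccc(-n4ccnc4)nn3)CC2)c1` gives 251 nM; the single matched step, a 6.4-fold higher number from compound 1 to compound 2 (0.81 log units; beyond the scatter), concerns only the aryl ether. Compound 3 `OCc1nnc(-c2ccc(N3CCC(Oc4ccccc4C(F)(F)F)CC3)nn2)s1`, which carries a trifluoromethyl on the aryl ether and a substituted five-membered ring on the shared core, gives 3.2 nM and holds the lowest number of the three, compound 1 being the nearest value and compound 2 the furthest, both beyond the scatter.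

Compound 4 `CC(C)(C)c1nnc(-c2ccc(N3CCC(Oc4ccccc4C(F)(F)F)CC3)nn2)s1` differs from compound 3 in one place: tert-butyl in place of hydroxymethyl on an aromatic carbon. Within the data shown here, no measured step touches this part of the molecule; the step from compound 1 to compound 2 sits on the aryl ether and offers no guide to a change on the five-membered ring. With nothing to compare against, a step within the scatter is expected, a 1.6-fold higher number from compound 3 to compound 4 (0.19 log units; within the scatter), in no preferred direction. Compound 4 is therefore estimated at 5 nM, with a range from 1.5 nM to 20 nM.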

Compound 4, half-maximal inhibitory concentration: 710 nM
Compound 4: middle estimate off by 140-fold (2.15 log units), on the low side; measured number outside the range, above it.
By their numbers in this assay, from the lowest: compound 3; then compound 1; then compound 2; then compound 4.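

In this assay, the change from 5-(hydroxymethyl)-1,3,4-thiadiazol-2-yl to 5-(tert-butyl)-1,3,4-thiadiazol-2-yl gives a 220-fold higher number from compound 3 to compound 4 (2.35 log units; beyond the scatter), so the number is highly sensitive to the group at this position for this pair. Hydroxymethyl has 2 heavy atoms, 1 hydrogen-bond donor and 1 hydrogen-bond acceptor, while tert-butyl has 4 heavy atoms and neither donor nor acceptor, so this one step changes all of these counts together and cannot separate them. Nothing available gives a reason for the step.

Open, on these data alone, is which of these differences matters: a methyl, a methoxymethyl or an aminomethyl at this carbon would begin to pull them apart. Also open, as far as these compounds go, is whether the same change would have a similar effect with the 2-methylphenyl ether of compound 1 in place of the trifluoromethyl-bearing aryl ether.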